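Chalcone series: chloro substitution on the phenyl ring

The source may report more compounds than this note shows. Statements on the series, on what has been measured and on what is new or still open speak of the compounds shown alone.

Measured compounds:
compound 1 `COc1cc(/C=C/C(=O)c2cccc(-n3cc(-c4ccccc4)[nH]c3=O)c2)ccc1O`, 3390 nM
compound 2 `COc1ccc(-c2cn(-c3cccc(C(=O)/C=C/c4cc(OC)c(OC)c(OC)c4)c3)c(=O)[nH]2)cc1`, 2660 nM

In a functional assay on NCI-H322M cells (Homo sapiens) for inhibition (a lower number here means a stronger inhibitor of growth, a higher number a weaker inhibitor of growth), compound 1 gives 3390 nM, the higher of the two numbers shown. Compound 2 gives 2660 nM, a gap within the scatter, so the two cannot be ordered. Compound 3 `COc1cc(/C=C/C(=O)c2cccc(-n3cc(-c4ccc(Cl)cc4)[nH]c3=O)c2)ccc1O` differs from compound 1 by chloro in place of hydrogen on an aromatic carbon. Among the measured compounds shown here, no step between measured compounds covers this change, so the expectation rests on compound 1 alone. For compound 3 the step of a 1.2-fold lower number from compound 1 to compound 3 (0.07 log units; within the scatter) is expected to stay within the scatter, with no clear direction. Compound 3 is estimated at 2900 nM, with a range from 1000 nM to 8500 nM.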

Compound 3, concentration for 50% growth inhibition: 4580 nM
Estimate against measurement, compound 3: 1.6-fold (0.20 log units) below; measured number inside the range.
By their numbers in this assay, from the lowest: compounds 2, 1 and 3 (each within the scatter of the next).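

In this assay, chloro in place of hydrogen on an aromatic carbon, para to a large group, gives a 1.4-fold higher number from compound 1 to compound 3 (0.13 log units; within the scatter). Among the compounds shown here, this is the first single-place step, and it shows that phenyl to 4-chlorophenyl leaves no readable change at this position. No measurement on hand bears on the reason for this result.

Open: whether a single chloro speaks for the whole position, since an amine or a carboxylic acid on the same carbon remains unseen. Also open, from the compounds shown here alone, is whether chloro on another carbon of this phenyl ring would give a step beyond the scatter.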